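The source may report more compounds than this note shows. Statements on the series, on what has been measured and on what is new or still open speak of the compounds shown alone.

Measured so far:
Compound 1 `OC1CCCN(c2nc(-c3ccccn3)nc3c2CN(Cc2ccccc2)CC3)C1`, in an assay on FRT cells with Cystic fibrosis transmembrane conductance regulator variant F508del (Homo sapiens) as the target, read by fluorescence, with a stated time of 25 min (a lower number here means a smaller maximal response, a higher number a larger maximal response), compound 1 gives 62.9%.
Compound 2 `NC(=O)C1CCN(c2nc(-c3ccccn3)nc3c2CN(Cc2ccccc2)CC3)CC1`, in this assay compound 2 gives 56.6%.

Compound 2 has the lower of the two numbers, yet the step of a number 6.3 percentage points lower from compound 1 to compound 2 (within the scatter) lies within the scatter, so the two cannot be told apart. Compound 3 `CN(C)CCN1CCN(c2nc(-c3ccccn3)nc3c2CN(Cc2ccccc2)CC3)CC1` differs from compound 2 by 4-(2-(dimethylamino)ethyl)piperazin-1-yl in place of 4-carbamoylpiperidin-1-yl on an aromatic carbon. For the measured compounds named here, the only measured step at this same place, a number 6.3 percentage points lower from compound 1 to compound 2 (within the scatter), was small, and no step covers the entering group itself. On that basis no change beyond the scatter is expected: compound 3 is estimated at 58%, between 40% and 76%, which means an expected step of a number 1.4 percentage points higher from compound 2 to compound 3 (within the scatter).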

Compound 3, largest response reached (Emax), in percent of the reference or control that the assay uses: 41.3%
Beside the measured number, compound 3's estimate is 16.7 percentage points above it; the range from low to high includes it.
By their numbers in this assay, from the lowest: compound 3; then compounds 2 and 1 (each within the scatter of the next).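

The group on this aromatic carbon can change the maximal response after all: in this assay, 4-(2-(dimethylamino)ethyl)piperazin-1-yl gives a number 15.3 percentage points lower from compound 2 to compound 3 (beyond the scatter) and a number 21.6 percentage points lower from compound 1 to compound 3 (beyond the scatter). The earlier swap between two piperidine groups had stayed within the scatter, so it gave no sign of this. Nothing shown here explains the difference.

The compounds shown leave open whether the piperazine ring or its 2-(dimethylamino)ethyl chain accounts for the step. A plain piperazin-1-yl or a 4-methylpiperazin-1-yl group at this place would separate the two.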